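From 2-chlorophenyl to 3-chlorophenyl on the shared core

A few compounds are considered here, and "the series" means these few. Any claim that something is new, unique, unknown or untested is made for them only; others in the source may bear on it.

In a functional assay on HepG2 cells (Homo sapiens) for inhibition, read by MTT assay, with a stated time of 72 h (on this read-out lower numbers stand for stronger inhibition and higher numbers for weaker inhibition), compound 1 `Cc1cc2occ(-c3nc(-c4ccccc4)c(-c4ccccc4)n3-c3ccc([N+](=O)[O-])cc3)c(=O)c2cc1Cl` gives 25000 nM, compound 2 `COc1ccccc1-n1c(-c2coc3cc(C)c(Cl)cc3c2=O)nc(-c2ccccc2)c1-c1ccccc1` gives 12500 nM and compound 3 `Cc1cc2occ(-c3nc(-c4ccccc4)c(-c4ccccc4)n3-c3ccccc3Cl)c(=O)c2cc1Cl` gives 6250 nM. Compound 3 thus stands clear of compound 1 but not of compound 2: a 4.0-fold lower number from compound 1 to compound 3 (0.60 log units; beyond the scatter) is beyond the scatter, while a 2.0-fold lower number from compound 2 to compound 3 (0.30 log units; within the scatter) is within it.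

Compound 4 `Cc1cc2occ(-c3nc(-c4ccccc4)c(-c4ccccc4)n3-c3cccc(Cl)c3)c(=O)c2cc1Cl` carries 3-chlorophenyl in place of 2-chlorophenyl on an aromatic nitrogen. Among the measured compounds shown here, no measured pair isolates this swap, so the evidence is indirect. The three measured steps all change the group on that same nitrogen. Besides the two above, a 2.0-fold lower number from compound 1 to compound 2 (0.30 log units; within the scatter) is also within the scatter, so the largest of the three is only modest.

A small upward drift towards the other values is therefore expected, but nothing beyond the scatter. In this assay the expected change is a 1.4-fold higher number from compound 3 to compound 4 (0.16 log units; within the scatter). The estimate for compound 4 is 9000 nM, with an expected range of 3500 nM to 22000 nM.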

Compound 4, half-maximal inhibitory concentration: 25000 nM
Compound 4: the middle estimate sits 2.8-fold (0.44 log units) below what was measured; measured number outside the range, above it.
By their numbers in this assay, from the lowest: compounds 3, 2, 1 and 4 (each within the scatter of the next, the first and the last beyond it).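

Among the compounds shown here, exchanging 2-chlorophenyl for 3-chlorophenyl on the aromatic nitrogen in this assay gives a 4.0-fold higher number from compound 3 to compound 4 (0.60 log units; beyond the scatter) and thus shows that, with the atoms unchanged, where the chlorine sits on this phenyl ring matters, which the earlier compounds, all differing in the group itself, could not show. The steps of a 2.0-fold higher number from compound 2 to compound 4 (0.30 log units; within the scatter) and no change at the digits printed from compound 1 to compound 4 (within the scatter) both lie within the scatter, so the gain of compound 3 over compound 1 belongs to 2-chlorophenyl and not to a chlorophenyl group as such. Nothing available explains this difference between the two chlorophenyl groups.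

The compounds shown leave open how 4-chlorophenyl on the same nitrogen would compare. They also leave open whether an amine or a carboxylic acid in place of the chlorine of compound 3 would keep its number.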